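The source may hold more compounds than are shown below. What is called first, only, known or untested is meant among the compounds shown, and "the series" means these compounds.

Compound 1, `COc1ccc(C)cc1N1C(=O)CSC1c1cccc(C(=O)NCCCCc2ccccc2)c1`, gives 92% in a functional assay on MG-63 cells (Homo sapiens) for inhibition, read by CCK-8 assay, with a stated time of 72 h, tested at 1 uM; a higher number here means more inhibition at the concentration tested (going by the name of the read-out), a lower number less inhibition.
Compound 2, `COc1ccc(OC)c(N2C(=O)CSC2c2cccc(C(=O)NCCCCc3ccccc3)c2)c1`, gives 92% in this assay.

Compound 2 stands level with compound 1 on these numbers: the step of no change at the digits printed from compound 1 to compound 2 (within the scatter) shows that putting a methoxy group where compound 1 carries a methyl group left the inhibition where it was. Compound 3, `COc1ccc(F)cc1N1C(=O)CSC1c1cccc(C(=O)NCCCCc2ccccc2)c1`, has not yet been tested in this assay. Its difference from compound 2 is fluoro in place of methoxy on an aromatic carbon. Among the compounds with values here, the one measured step, from compound 1 to compound 2, also exchanged a small group on an aromatic carbon of the same ring, and it stayed within the scatter. Within the data shown here, no measured pair exchanges methoxy for fluoro, so the expectation rests on that single step alone. Because no change at the digits printed from compound 1 to compound 2 (within the scatter) was flat, compound 3 is expected to sit close to compound 2, and the step of a number 3 percentage points lower from compound 2 to compound 3 (within the scatter) is expected to stay within the scatter. The estimate for compound 3 in this assay is therefore 89%, with a range from 76% to 96%.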

Compound 3, a percentage reported as inhibition, at one concentration (the size of the read-out at that concentration, not a potency): 86%
Beside the measured number, compound 3's estimate is 3 percentage points above it, and the stated range covers the measured number.
By their numbers in this assay, from the lowest: compounds 3, 1 and 2 (each within the scatter of the next).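

Fluoro is a smaller group than the methoxy it replaces, with one heavy atom instead of two and no hydrogen-bond acceptor, yet in this assay this exchange gives a number 6 percentage points lower from compound 2 to compound 3 (within the scatter) and the exchange of methyl for fluoro gives a number 6 percentage points lower from compound 1 to compound 3 (within the scatter) in the same place. This position, para to a methoxy group, has now carried three different groups, and the three compounds all lie within the scatter of one another, so the flat result of the first step is no longer a finding about a single pair. No measurement is available that could explain why the inhibition in this assay stays level across these three compounds.

The read-out comes from a single concentration, so these figures leave open whether the three compounds also match in potency, which a full dose-response curve would be needed to show. As far as these compounds go, it is also open whether the position accepts groups of quite another kind, such as an amine, a carboxylic acid or a longer chain like butoxy, as readily as it accepts these small ones.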